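Ether chain length on the shared core against kynurenine 3-monooxygenase

The source may hold more compounds than are shown below. What is called first, only, known or untested is meant among the compounds shown, and "the series" means these compounds.

Two compounds of the series carry numbers in an assay on HEK293 cells for inhibition of kynurenine 3-monooxygenase (Homo sapiens), read by LC-MS, with a stated time of 20 h; a higher number here means a weaker inhibitor, a lower number a stronger inhibitor. Compound 1 `COCCOc1cc2oc(=O)n(CCC(=O)O)c2cc1Cl` gives 50100 nM. For the measured compounds named here, compound 2 `COc1cc2oc(=O)n(CCC(=O)O)c2cc1Cl` gives 5010 nM, the lowest of the two numbers so far; its nearest neighbour is compound 1, and the single step between them, hydrogen in place of methoxymethyl on the chain carbon attached to the aromatic oxygen, reads a 10-fold lower number from compound 1 to compound 2 (1.00 log units; beyond the scatter).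

Compound 3 `CCOc1cc2oc(=O)n(CCC(=O)O)c2cc1Cl` has not been measured. It differs from compound 2 by methyl in place of hydrogen on a saturated chain carbon bound to an oxygen on an aromatic ring; cut one bond further out, the change reads methyl to ethyl, methoxy to ethoxy. Going by the values given here, only one measured step bears on it: removing the methoxymethyl group gave a 10-fold lower number from compound 1 to compound 2 (1.00 log units; beyond the scatter), so lengthening the ether chain on this carbon raised the number by that amount. A methyl is a shorter addition than methoxymethyl, so the expected movement for compound 3 is a rise in this assay smaller than that step, estimated as a 1.8-fold higher number from compound 2 to compound 3 (0.25 log units; within the scatter). Compound 3 is therefore expected to give about 9000 nM, with a plausible range from 3500 nM to 25000 nM.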

Compound 3, half-maximal inhibitory concentration: 398 nM
For compound 3 the middle estimate is 23-fold (1.35 log units) above the measured one; measured number outside the range, below it.
By their numbers in this assay, from the lowest: compound 3; then compound 2; then compound 1.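

In this assay, the number at this saturated chain carbon bound to an oxygen on an aromatic ring does not rise steadily with the length of the ether chain. Methyl in place of hydrogen gives a 13-fold lower number from compound 2 to compound 3 (1.10 log units; beyond the scatter). That change runs opposite to the rise seen from compound 2 to compound 1. Hydrogen in place of methoxy, on a saturated chain carbon two bonds along the chain from an oxygen on an aromatic ring, gives a 130-fold lower number from compound 1 to compound 3 (2.10 log units; beyond the scatter) and shows how much the outer methoxy costs on the ethoxy compound. The order therefore does not follow chain length: compound 2, with the shortest chain, lies between compound 3 and compound 1, and no measurement shown gives a reason for this turn in direction.

Still open, as far as these compounds go, is whether the low number of compound 3 persists with a longer all-carbon chain such as propyl or butyl, or is specific to ethyl. Also open, from the compounds shown here alone, is how branched or ring-bearing groups such as isopropyl or cyclopropylmethyl behave at this carbon.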